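The source may hold more compounds than are shown below. What is called first, only, known or untested is meant among the compounds shown, and "the series" means these compounds.

Compound 1 `COC(=O)c1sc2cc(C#Cc3cccc(N)c3)cnc2c1N` gives 11500 nM in a functional assay on NCI-H460 cells (Homo sapiens) for inhibition, read by sulforhodamine B assay, with a stated time of 48 h; on this read-out higher numbers stand for weaker inhibition of growth and lower numbers for stronger inhibition of growth.
Compound 2 `COC(=O)c1sc2cc(C#Cc3ccc(N)cc3)cnc2c1N` gives 8900 nM in this assay.
Compound 3 `COC(=O)c1sc2cc(C#Cc3ccccc3OC)cnc2c1N` gives > 47300 nM in this assay, which is a limit of the assay rather than a number.

Of the three measured compounds, compound 3 is the one that sits at the limit (the limit of > 47300 nM in this assay, at which 1 of the 3 values shown sits), so only a floor for its number is known. Compound 4 `COC(=O)c1sc2cc(C#Cc3cccnc3)cnc2c1N` differs from compound 3 by a single exchange: pyridin-3-yl in place of 2-methoxyphenyl on a triple-bonded carbon. Within the data shown here, two measured steps bear on this change, since both end in the group that now leaves: an at least 4.1-fold higher number from compound 1 to compound 3 (0.61 log units; beyond the scatter) and an at least 5.3-fold higher number from compound 2 to compound 3 (0.72 log units; beyond the scatter). Both went toward weaker inhibition and both lie beyond the scatter. Undoing that group in the step to compound 4 is therefore expected to move the number down, toward stronger inhibition. Compound 4 is expected to give 20000 nM, with a range from 7000 nM to 60000 nM. That estimate means an at least 2.3-fold lower number from compound 3 to compound 4 (0.37 log units; beyond the scatter), a step expected to lie beyond the scatter.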

Compound 4, concentration for 50% growth inhibition: > 150000 nM
Compound 4 gave a limit, no number; the forecaster's own chance of this, stated with the estimate: 30%; middle value at least 7.5-fold (0.87 log units) away from the limit.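

On the triple-bonded carbon, pyridin-3-yl gives far weaker inhibition of growth than 4-aminophenyl (an at least 16-fold higher number from compound 2 to compound 4 (1.22 log units; beyond the scatter)) and than 3-aminophenyl (an at least 13-fold higher number from compound 1 to compound 4 (1.11 log units; beyond the scatter)). Weak inhibition is therefore not tied to 2-methoxyphenyl alone: compound 4, whose ring holds a hetero atom and no amino group, also ends at a limit of the assay. Compound 3 and compound 4 both stand at limits, and the step between them cannot be read.

Going by these compounds, how a plain phenyl or a phenyl carrying a hydroxyl group would behave here stays open. So does whether an amino group on a pyridine ring would bring back measurable inhibition.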